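The compounds below may be only part of what the source reports. "The series", "measured", "known", "first", "only" and "open" are said of these compounds alone.

Compound 3 `CSc1nn2c(C)ccnc2c1S(=O)(=O)c1ccccc1` gives 22.9 nM in a functional assay on HEK293 cells for antagonist activity at 5-hydroxytryptamine receptor 6 (Homo sapiens), read by cAMP accumulation, with a stated time of 2 h (a lower number here means a stronger inhibitor, a higher number a weaker inhibitor), the second highest of the three numbers recorded: compound 1 `CSc1nn2cccnc2c1S(=O)(=O)c1ccccc1` gives 115 nM and compound 2 `CSc1nn2c(C)cc(C)nc2c1S(=O)(=O)c1ccc(O)cc1` gives 3.98 nM. For the measured compounds named here, the only single-point step measured so far, a 5.0-fold lower number from compound 1 to compound 3 (0.70 log units; beyond the scatter), shows a methyl on the fused core lowering the number. Compound 4 `CSc1nn2c(C)cc(CO)nc2c1S(=O)(=O)c1ccccc1` differs from compound 3 by hydroxymethyl in place of hydrogen on an aromatic carbon. Going by the values given here, no measured step covers a hydroxymethyl at this ring carbon; compound 2 carries a methyl in place of that same hydrogen together with a hydroxyl on the phenyl, and its number is lower than that of compound 3, but the pair differs in two places. A smaller gain than in the methyl step is therefore expected for compound 4, a 1.9-fold lower number from compound 3 to compound 4 (0.28 log units; within the scatter). Compound 4 is estimated at 12 nM, range 4 nM to 40 nM.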

Compound 4, inhibition constant: 2.14 nM
Compound 4: middle estimate off by 5.6-fold (0.75 log units), on the high side; measured number below the stated range.
By their numbers in this assay, from the lowest: compounds 4 and 2 (each within the scatter of the next); then compound 3; then compound 1.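

Hydroxymethyl in place of hydrogen on this aromatic carbon, next to the ring nitrogen, lowers the number substantially (an 11-fold lower number from compound 3 to compound 4 (1.03 log units; beyond the scatter)). This position of the shared core therefore tolerates a group with a hydrogen-bond donor and acceptor, and the step is beyond the scatter. Nothing available explains the size of this step.

Open, on these data alone, is whether the gain requires the hydroxyl, which a methyl alone at this carbon, with the phenyl unchanged, would test. Also open, as far as these compounds go, is how an amine, a carboxylic acid or a longer chain such as hydroxyethyl would behave here.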